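The compounds below may be only part of what the source reports. "The series", "measured", "known", "first", "only" and "open" are said of these compounds alone.

Measured compounds in an ADME assay on RAW264.7 cells (Mus musculus) for cytotoxicity, read by MTT assay, with a stated time of 48 h, tested at 50 uM; a higher number here means more inhibition at the concentration tested (going by the name of the read-out), a lower number less inhibition:
compound 1, `N=C1S/C(=C\c2ccc(OCc3ccccc3)cc2)C(=O)N1c1ccc(F)cc1`, 10.5%
compound 2, `N=C1S/C(=C\c2ccc(OCc3ccccc3)cc2)C(=O)N1c1ccc(Cl)cc1Cl`, 13.8%
compound 3, `Cc1cccc(N2C(=N)S/C(=C\c3ccc(OCc4ccccc4)cc3)C2=O)n1`, 25.1%

Compound 1 gives the lowest of the three numbers; compound 2 sits within the scatter of it, compound 3 beyond it. Compound 4, `Cc1ccc(N2C(=N)S/C(=C\c3ccc(OCc4ccccc4)cc3)C2=O)c(C)c1`, differs from compound 1 by 2,4-dimethylphenyl in place of 4-fluorophenyl on an amide-type nitrogen in a ring. Within the data shown here, two measured steps bear on this, both changing the group on the same nitrogen: a number 3.3 percentage points higher from compound 1 to compound 2 (within the scatter), and a number 14.6 percentage points higher from compound 1 to compound 3 (beyond the scatter). The larger step came with a heteroaryl ring; the carbocyclic swap stayed within the scatter, and the dimethylphenyl of compound 4 is carbocyclic. Compound 4 is therefore expected to give 13% in this assay, between 3% and 25%, which means an expected step of a number 2.5 percentage points higher from compound 1 to compound 4 (within the scatter), not beyond the scatter.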

Compound 4, a percentage reported as inhibition, at one concentration (the size of the read-out at that concentration, not a potency): 36.8%
Compound 4: middle estimate off by 23.8 percentage points, on the low side, and the stated range ends below it.
By their numbers in this assay, from the lowest: compounds 1 and 2 (each within the scatter of the next); then compound 3; then compound 4.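

In this assay, a carbocyclic ring on this nitrogen is not confined to small steps: 2,4-dimethylphenyl gives a number 26.3 percentage points higher from compound 1 to compound 4 (beyond the scatter), and a number 11.7 percentage points higher from compound 3 to compound 4 (beyond the scatter), so the heteroaryl ring of compound 3 is not needed for a high number here. The exchange of chlorine for methyl on the same 2,4-disubstituted phenyl ring gives a number 23 percentage points higher from compound 2 to compound 4 (beyond the scatter), so the substituents, and not only their number, matter at this position. Nothing available explains these differences. Going by these compounds, it remains open whether both methyl groups are needed, and how a phenyl ring carrying an amine, a carboxylic acid or a longer alkyl chain would read.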